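Series notes: cytotoxicity ahead of the fluoro analogue

The compounds below may be only part of what the source reports. "The series", "measured", "known", "first", "only" and "open" are said of these compounds alone.

Measured so far:
- compound 1, `Cc1ccc(NC(=O)c2cccc(/C=C3\CC(=O)N(c4ccccc4)C3=O)c2)cc1`: in an ADME assay on HCT-116 cells (Homo sapiens) for cytotoxicity, read by MTT assay, with a stated time of 72 h (a lower number here means a stronger inhibitor, a higher number a weaker inhibitor), compound 1 gives > 100000 nM, a limit of the assay and not a number.
- compound 2, `Cc1cccc(NC(=O)c2cccc(/C=C3\CC(=O)N(c4ccccc4)C3=O)c2)c1`: in this assay compound 2 gives > 100000 nM, again a limit.
- compound 3, `CCCCNC(=O)c1cccc(/C=C2\CC(=O)N(Cc3ccccc3)C2=O)c1`: in this assay compound 3 gives 95100 nM.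

Going by the values given here, compound 1 thus stands at a limit, and the only step measured from it, a step that the two limits leave unreadable from compound 1 to compound 2, cannot be read, since both ends sit at the limit of > 100000 nM in this assay, at which 2 of the 3 values shown sit. Compound 4 `O=C(Nc1ccc(F)cc1)c1cccc(/C=C2\CC(=O)N(c3ccccc3)C2=O)c1` differs from compound 1 by fluoro in place of methyl on an aromatic carbon. Among the compounds with values here, no measured step covers fluoro in place of methyl, so for a number no higher from compound 1 to compound 4 (the limit leaves the size open) no change beyond the scatter is expected. Compound 4 is therefore estimated at 100000 nM, with a range from 50000 nM to 200000 nM, most likely reported again only as a limit.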

Compound 4, half-maximal inhibitory concentration: > 100000 nM
Compound 4 gave a limit, no number; the forecaster's own chance of this, stated with the estimate: 70%; the middle value sits exactly at the limit.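

Compound 4 gives only a limit, as do compound 1 and compound 2, so no step among these three can be read: the limit of > 100000 nM in this assay, at which 3 of the 4 values shown sit.
Going by these compounds, whether fluoro in place of methyl changes the read-out in this assay at all remains open.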